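The compounds below may be only part of what the source reports. "The series", "measured", "known", "first", "only" and "open" are said of these compounds alone.

Of the compounds shown here, three built on one shared core have been tested in a functional assay on HepG2 cells (Homo sapiens) for antiproliferative activity, read by MTT assay, with a stated time of 48 h; a lower number here means a stronger inhibitor, a higher number a weaker inhibitor. Compound 1 `CCOc1ccccc1-n1nncc1CN1C(=O)C2(C(C#N)=C(N)Oc3c2c2nc4ccccc4nc2c2ccccc32)c2ccccc21` carries a 2-ethoxyphenyl on an aromatic nitrogen. In this assay compound 1 gives > 50000 nM, which is a limit of the assay and not a number. Compound 2 `N#CC1=C(N)Oc2c(c3nc4ccccc4nc3c3ccccc23)C12C(=O)N(Cc1cnnn1-c1ccc(Cl)c(Cl)c1)c1ccccc12` carries a 3,4-dichlorophenyl at the same place. In this assay compound 2 gives > 50000 nM, again a limit rather than a number. The step that the two limits leave unreadable from compound 1 to compound 2 therefore cannot be read in either direction. Compound 3 `CC(=O)Nc1ccc(-n2nncc2CN2C(=O)C3(C(C#N)=C(N)Oc4c(N)cc5nc6ccccc6nc5c43)c3ccccc32)cc1` carries a 4-acetamidophenyl on that aromatic nitrogen. In this assay compound 3 gives > 50000 nM, once more a limit and not a number. Compound 3 thus stands where all three values stand: at the limit of > 50000 nM in this assay, at which 3 of the 3 values shown sit.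

Compound 4 `N#CC1=C(N)Oc2c(N)cc3nc4ccccc4nc3c2C12C(=O)N(Cc1cnnn1-c1ccc([N+](=O)[O-])cc1[N+](=O)[O-])c1ccccc12` has not yet been measured. It differs from compound 3 by 2,4-dinitrophenyl in place of 4-acetamidophenyl on an aromatic nitrogen. Going by the values given here, no measured step involves either the 4-acetamidophenyl or the 2,4-dinitrophenyl, and the one measured step is unreadable, so there is no numerical guide to the size or direction of this change. Given that every value so far sits at the limit, compound 4 is expected to sit there too, and the step of a number no higher from compound 3 to compound 4 (the limit leaves the size open) is estimated to be none beyond the scatter. For compound 4 the estimate is 50000 nM, with a range from 15000 nM to 150000 nM.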

Compound 4, half-maximal inhibitory concentration: 18400 nM
Compound 4: the middle estimate sits 2.7-fold (0.43 log units) above what was measured; measured number inside the range.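

In this assay, the group on the aromatic nitrogen of the five-membered ring can decide whether a compound gives a readable number at all: putting 2,4-dinitrophenyl in place of 4-acetamidophenyl produces an at least 2.7-fold lower number from compound 3 to compound 4 (0.43 log units; beyond the scatter). Compound 3 has only a limit and not a number, so this step sets a minimum size, and the true gap may be wider. Before this result, the one step at this position between compounds with the same core could not be read in either direction, whereas this one has a direction, and compound 4 is the only compound shown that comes off the limit: the limit of > 50000 nM in this assay, at which 3 of the 4 values shown sit.

The change removes an acetamido group and adds two nitro groups at once, so the compounds shown cannot separate the effect of each nitro group, and a 4-nitrophenyl or 2-nitrophenyl carrying a single nitro group at this place would be needed to do so. As far as these compounds go, it also remains open whether other groups on this phenyl ring, such as a primary amine or a carboxylic acid, would give a number in this assay. From the compounds shown here alone, compound 4 gives 18400 nM, and how any such number would compare with it is equally open.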